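A few compounds are considered here, and "the series" means these few. Any claim that something is new, unique, unknown or untested is made for them only; others in the source may bear on it.

The measured compounds in a functional assay (aorta) with Rattus norvegicus as the target; on this read-out lower numbers stand for an effect already at smaller amounts and higher numbers for an effect only at larger amounts of compound:
- compound 1, `C/N=C(/NC)Nc1nc(-c2ccc(OC)cc2)c(-c2ccc(OC)cc2)s1`: 2.4 uM
- compound 2, `CCOC(=O)/C=C/c1nc(-c2ccc(OC)cc2)c(-c2ccc(OC)cc2)s1`: > 100 uM, a limit of the assay and not a number
- compound 3, `COc1ccc(-c2nc(/C=C/C(=O)O)sc2-c2ccc(OC)cc2)cc1`: 55 uM

Of the two actual numbers, compound 1 has the lowest; its nearest neighbour is compound 3, reached by a 23-fold higher number from compound 1 to compound 3 (1.36 log units; beyond the scatter). Compound 2 sits at the limit of > 100 uM in this assay, at which 1 of the 3 values shown sits.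

The unmeasured compound 4, `COc1ccc(-c2nc(CCC(=O)O)sc2-c2ccc(OC)cc2)cc1`, arises from compound 1 by a group of 5 heavy atoms (3 carbon, 2 oxygen; no ring) in place of a group of 6 heavy atoms (3 carbon, 3 nitrogen; no ring), on an aromatic carbon. The step that bears most directly on this change is the one in which the same leaving group gives way to a closely related acid-bearing chain: a 23-fold higher number from compound 1 to compound 3 (1.36 log units; beyond the scatter), a large rise. The ester-to-acid change gave an at least 1.8-fold lower number from compound 2 to compound 3 (0.25 log units; that floor lies within the scatter), so that part of the structure hardly moves the read-out. For the measured compounds named here, the only remaining difference, a saturated chain in compound 4 against an unsaturated one in compound 3, is covered by no measured step. The expectation for compound 4 is therefore a large rise in this assay, a 21-fold higher number from compound 1 to compound 4 (1.32 log units; beyond the scatter). The estimate for compound 4 is 50 uM, with a range from 15 uM to 150 uM.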

Compound 4, concentration for half-maximal effect: > 100 uM
Compound 4 ended at the assay's limit (the forecaster's own chance of this, stated with the estimate: 20%); at least 2.0-fold (0.30 log units) between middle value and limit.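

Compound 4 gives a limit of the assay and not a number, and compound 2 gives the same limit in this assay: the limit of > 100 uM in this assay, at which 2 of the 4 values shown sit.

Placing 2-carboxyethyl on this aromatic carbon gives an at least 41-fold higher number from compound 1 to compound 4 (1.61 log units; beyond the scatter), so a second chain ending in a carboxylic acid, after the 2-carboxyethenyl of compound 3, also stands far from compound 1. Removing the double bond from the chain gives an at least 1.8-fold higher number from compound 3 to compound 4 (0.25 log units; that floor lies within the scatter), so this floor does not separate the saturated chain from the unsaturated one, and the step between compound 2 and compound 4 cannot be read.

The compounds shown include no simple amine on this carbon and no longer chain ending in a carboxylic acid, so it stays open which part of the group in compound 1 goes with its lower number. From the compounds shown here alone, how far compound 4 lies from compound 2 also stays open.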